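The source may report more compounds than this note shows. Statements on the series, on what has been measured and on what is new or still open speak of the compounds shown alone.

Compound 3 `Clc1ccc(C2=NN(C3=NC(c4ccccc4)CS3)C(c3ccc4ccccc4c3)C2)cc1` is measured in a functional assay on HepG2 cells (Homo sapiens) for inhibition, read by CCK-8 assay, with a stated time of 48 h (a higher number here means a weaker inhibitor, a lower number a stronger inhibitor), where compound 3 gives 22100 nM. Compound 1 `Fc1ccc(C2=NN(C3=NC(c4ccccc4)CS3)C(c3cccc4ccccc34)C2)cc1` gives 23200 nM in this assay, and compound 2 `O=C1CSC(N2N=C(c3ccc(Cl)cc3)CC2c2ccc3ccccc3c2)=N1` gives 20400 nM; all three numbers lie within the scatter of one another. For the measured compounds named here, the one measured step, a 1.1-fold higher number from compound 2 to compound 3 (0.03 log units; within the scatter), changed a different part of the molecule and does not bear on the present change. Compound 4 `Fc1ccc(C2=NN(C3=NC(c4ccccc4)CS3)C(c3ccc4ccccc4c3)C2)cc1` differs from compound 3 in one place: fluoro in place of chloro on an aromatic carbon. Compound 1 also carries fluoro, and its number sits within the scatter of compound 3, so nothing here points to a shift. The expected step is a 1.0-fold lower number from compound 3 to compound 4 (0.00 log units; within the scatter), none beyond the scatter. Compound 4 is therefore estimated at 22000 nM, in a range from 11000 nM to 44000 nM.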

Compound 4, half-maximal inhibitory concentration: 26500 nM
Beside the measured number, compound 4's estimate is 1.2-fold (0.08 log units) below it, and the stated range covers the measured number.
By their numbers in this assay, from the lowest: compounds 2, 3, 1 and 4 (each within the scatter of the next).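

At this 4-substituted phenyl position, fluoro in place of chloro leaves the number in this assay within the scatter (a 1.2-fold higher number from compound 3 to compound 4 (0.08 log units; within the scatter)). For the compounds shown here, the first direct comparison of naphthalen-2-yl with naphthalen-1-yl on the saturated ring carbon also stays within the scatter (a 1.1-fold higher number from compound 1 to compound 4 (0.06 log units; within the scatter)). Nothing measured here gives a reason for either result. The compounds shown leave open whether methoxy, an amine or a carboxylic acid on this aromatic carbon would move the number beyond the scatter. They also leave open whether any change to the shared core would do so.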